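Compound 3 to compound 4: a change on the amide nitrogen

A few compounds are considered here, and "the series" means these few. Any claim that something is new, unique, unknown or untested is made for them only; others in the source may bear on it.

Compound 1 `COc1ccc2c(=O)c(/C=C/C(=O)Nc3cccc(Cl)c3)coc2c1`: 11900 nM
Compound 2 `COc1ccc2c(=O)c(/C=C/C(=O)Nc3ccccc3)coc2c1`: > 100000 nM (a limit of the assay)
Compound 3 `COc1cccc(NC(=O)/C=C/c2coc3cc(OC)ccc3c2=O)c1`: 19200 nM

All three compounds were tested in a functional assay on HeLa cells (Homo sapiens) for inhibition, read by MTT assay, with a stated time of 48 h; on this read-out lower numbers stand for stronger inhibition and higher numbers for weaker inhibition. For compound 2 the entry > 100000 nM is a limit and not a number. Compound 3, at 19200 nM, stands level with compound 1, since the measured gap is a 1.6-fold higher number from compound 1 to compound 3 (0.21 log units; within the scatter). Two larger steps involve compound 2: an at least 8.4-fold higher number from compound 1 to compound 2 (0.92 log units; beyond the scatter) and an at least 5.2-fold lower number from compound 2 to compound 3 (0.71 log units; beyond the scatter). Both exchange a group on an aromatic carbon, so neither tests the change that follows.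

That change leads to compound 4 `COc1ccc2c(=O)c(/C=C/C(=O)NCc3cccc(F)c3)coc2c1`: 3-fluorobenzyl in place of 3-methoxyphenyl on an amide-type nitrogen. Among the measured compounds shown here, it puts 3-fluorobenzyl in place of 3-methoxyphenyl on an amide-type nitrogen, and no measured step covers such an exchange. For the measured compounds named here, the steps to compound 2, an at least 8.4-fold higher number from compound 1 to compound 2 (0.92 log units; beyond the scatter) and an at least 5.2-fold lower number from compound 2 to compound 3 (0.71 log units; beyond the scatter), show only that a single change can move the value widely, so the expectation stays loose. The expected change is a 1.4-fold higher number from compound 3 to compound 4 (0.13 log units; within the scatter), with no clear step beyond the scatter anticipated. For compound 4 the estimated value is 26000 nM, with an expected range from 7000 nM to 90000 nM.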

Compound 4, half-maximal inhibitory concentration: 17600 nM
Compound 4: middle estimate off by 1.5-fold (0.17 log units), on the high side, and the stated range covers the measured number.
By their numbers in this assay, from the lowest: compounds 1, 4 and 3 (each within the scatter of the next). At a limit, above all of these: compound 2.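

In this assay the group on the amide nitrogen proves open to a larger exchange than the earlier aromatic-carbon changes tested: 3-fluorobenzyl in place of 3-methoxyphenyl stays within the scatter (a 1.1-fold lower number from compound 3 to compound 4 (0.04 log units; within the scatter)), and the same holds for 3-fluorobenzyl in place of 3-chlorophenyl (a 1.5-fold higher number from compound 1 to compound 4 (0.17 log units; within the scatter)). The step from the phenyl amide, by contrast, lies beyond the scatter (an at least 5.6-fold lower number from compound 2 to compound 4 (0.75 log units; beyond the scatter)), which places compound 4 with compounds 1 and 3 and apart from compound 2. The entry for compound 2 is a limit of the assay and not a number: (the limit of > 100000 nM in this assay, at which 1 of the 4 values shown sits).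

Still open, on these data alone, is whether the fluoro group contributes anything, which a plain benzyl group on the same nitrogen would test. Also open, as far as these compounds go, is whether a longer chain, such as phenethyl, or a group carrying an amine would hold the value at this level.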